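The source may hold more compounds than are shown below. What is called first, only, known or untested is meant among the compounds shown, and "the series" means these compounds.

Compound 1 `CC1CCC(C(=O)N2CC(c3nc(-c4cccc(Cl)c4)no3)C2)CC1` reaches only the edge of measurement: in an assay on HEK293 cells for negative allosteric modulation of metabotropic glutamate receptor 5 (Homo sapiens), read by FLIPR (on this read-out lower numbers stand for stronger inhibition and higher numbers for weaker inhibition), compound 1 gives > 10000 nM, which is a limit of the assay and not a number. Compound 2 `Cc1cccc(-c2noc(C3CN(C(=O)C4CCC(C(F)(F)F)CC4)C3)n2)c1` stands in the same place, since in this assay compound 2 gives > 10000 nM, again a limit rather than a number. Both values sit at the limit of > 10000 nM in this assay, at which 2 of the 2 values shown sit. Compound 3 `O=C(C1CCC(C(F)(F)F)CC1)N1CC(c2nc(-c3cccc(Cl)c3)no2)C1` carries chloro in place of methyl on an aromatic carbon. For the measured compounds named here, no measured step covers this change, and compound 1, which already carries the 3-chlorophenyl, sits at the limit, so the expected step that the limit leaves unreadable from compound 2 to compound 3 is none beyond the scatter. Compound 3 is expected to give 15000 nM, in a range from 5000 nM to 50000 nM, most likely again reported as a limit.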

Compound 3, half-maximal inhibitory concentration: > 10000 nM
Compound 3: only a limit was reported (the forecaster's own chance of this, stated with the estimate: 85%); the middle value lies beyond the limit too.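

No step can be read from compound 1 or compound 2 to compound 3, because all three stop at the same limit: the limit of > 10000 nM in this assay, at which 3 of the 3 values shown sit. The compounds shown leave open how strongly any of them inhibits in this assay, and whether chloro or methyl, or trifluoromethyl or methyl, makes any difference there.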